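The source may hold more compounds than are shown below. What is called first, only, known or untested is meant among the compounds shown, and "the series" means these compounds.

Measured so far:
compound 1 `COc1ccc(F)cc1CNCCCNc1ccnc2cc(Cc3cc(C)cc(C)c3)ccc12` — 940 nM
compound 2 `COc1ccc(-c2ccc3c(NCCCNCc4cc(F)ccc4OC)ccnc3c2)cc1` — 5960 nM

Going by the values given here, in an ADME assay on HepG2 cells (Homo sapiens) for cytotoxicity, read by luminescence, CellTiter-Glo and ATP content, with a stated time of 72 h (a lower number here means that less compound is needed, a higher number that more compound is needed for the effect), compound 2 stands at the highest of the two numbers so far; its nearest neighbour is compound 1, with the step of a 6.3-fold higher number from compound 1 to compound 2 (0.80 log units; beyond the scatter) separating them. That step, 4-methoxyphenyl in place of 3,5-dimethylbenzyl on an aromatic carbon, is the only one on record, and it runs toward a higher number.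

Compound 3 `COc1ccc(F)cc1CNCCCNc1ccnc2cc(CC3CCCCC3)ccc12` has not been measured. It differs from compound 2 by cyclohexylmethyl in place of 4-methoxyphenyl on an aromatic carbon. Among the compounds with values here, the one relevant step, a 6.3-fold higher number from compound 1 to compound 2 (0.80 log units; beyond the scatter), went from a methylene-linked ring to a ring bound directly to the aromatic carbon; compound 3 reverses that arrangement, returning to a methylene-linked ring, now a non-aromatic one. On that basis the step is expected to run back toward a lower number, of a size similar to the earlier one though less certain, since the entering ring is not the one that left in that step.

The expected step for compound 3 is a 4.0-fold lower number from compound 2 to compound 3 (0.60 log units; beyond the scatter), estimated from the size of a 6.3-fold higher number from compound 1 to compound 2 (0.80 log units; beyond the scatter). Compound 3 is therefore expected to give about 1500 nM in this assay, with a range of 500 nM to 4500 nM.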

Compound 3, half-maximal effective concentration: 1830 nM
For compound 3 the middle estimate is 1.2-fold (0.09 log units) below the measured one; measured number inside the range.
By their numbers in this assay, from the lowest: compounds 1 and 3 (each within the scatter of the next); then compound 2.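

In this assay, cyclohexylmethyl in place of 4-methoxyphenyl on this aromatic carbon gives a 3.3-fold lower number from compound 2 to compound 3 (0.51 log units; beyond the scatter) and so separates a second methylene-linked ring, here a non-aromatic one, from the directly bound ring of compound 2. The two methylene-linked rings are not separated from each other: cyclohexyl in place of 3,5-dimethylphenyl gives a 1.9-fold higher number from compound 1 to compound 3 (0.29 log units; within the scatter), so at this position, among these three compounds, swapping the aromatic ring with its two methyl groups for a saturated ring of carbon only leaves the read-out unresolved, and compound 2 alone stands apart. No measurement at hand accounts for any of these differences.

Still open is whether the separation of compound 2 follows the directly bound ring or its methoxy group, as both change together in the steps shown; a cyclohexyl bound directly to the aromatic carbon and an unsubstituted phenyl would help to tell these apart. Also open, as far as these compounds go, is how the read-out in this assay responds to a longer chain between ring and core, or to an amine or a carboxylic acid on the ring.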